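Methyl on the core: notes on an inactive pair

The source may report more compounds than this note shows. Statements on the series, on what has been measured and on what is new or still open speak of the compounds shown alone.

Compound 1, `C=CCn1ncc2cnc(Cc3ccccc3)n2c1=O`, gives > 48000 nM in a functional assay for inhibition, with Homo sapiens as the target; a higher number here means a weaker inhibitor, a lower number a stronger inhibitor; this value is a limit of the assay, not a number.
Compound 2, `C=CCn1ncc2cncn2c1=O`, gives > 48000 nM in this assay; this too is a limit of the assay.

Compound 2 therefore stands at the ceiling of what was measured: the limit of > 48000 nM in this assay, at which 2 of the 2 values shown sit. No numerical inhibition has been recorded for it, and nothing measured separates it from compound 1.

The next member, compound 3, is `C=CCn1ncc2cnc(C)n2c1=O`. It differs from compound 2 by methyl in place of hydrogen on an aromatic carbon. Among the compounds with values here, no measured step of this kind exists, so the expectation rests only on the two limits seen so far. Compound 1, which carries a larger group on the same core, also sits at the limit, and a methyl is not expected to move compound 3 beyond the scatter in this assay. Compound 3 is accordingly estimated at 48000 nM, with a range from 20000 nM to 100000 nM. The expected step is a number no higher from compound 2 to compound 3 (the limit leaves the size open), and the most probable outcome is that the assay again reports only a limit.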

Compound 3, half-maximal inhibitory concentration: > 48000 nM
Compound 3: no number, only a limit; the forecaster's own chance of this, stated with the estimate: 85%; the middle value sits exactly at the limit.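

In this assay compound 3 gives only a limit of the assay, as do compound 1 and compound 2, so no step among these compounds can be read: the limit of > 48000 nM in this assay, at which 3 of the 3 values shown sit.

On these data alone, whether this assay returns a number for any group on the shared core remains open.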